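The source may hold more compounds than are shown below. What is called first, only, known or untested is meant among the compounds shown, and "the series" means these compounds.

Compound 3 `COc1ccc(-c2ccc(-c3ccc(-c4nc5c(O)cccc5[nH]4)cc3)cc2)cc1` gives 8640 nM in a functional assay on A2780 cells (Homo sapiens) for inhibition, read by sulforhodamine B assay (a lower number here means a stronger inhibitor of growth, a higher number a weaker inhibitor of growth), and is the reference here. Compound 1 `Oc1cccc2[nH]c(-c3ccc(-c4ccc(-c5ccc(C(F)(F)F)cc5)cc4)cc3)nc12` gives 6100 nM with a 1.4-fold higher number from compound 1 to compound 3 (0.15 log units; within the scatter) as the gap. Compound 2 `Oc1ccc(-c2ccc(-c3ccc(-c4nc5c(O)cccc5[nH]4)cc3)cc2)cc1` gives 2920 nM and stands apart, with a 3.0-fold higher number from compound 2 to compound 3 (0.47 log units; beyond the scatter) as its gap and a 2.1-fold lower number from compound 1 to compound 2 (0.32 log units; beyond the scatter) on the other side. Compound 4 `COc1ccc(-c2ccc(-c3ccc(-c4nc5c(O)cccc5[nH]4)cc3)cc2)cc1OC` carries methoxy in place of hydrogen on an aromatic carbon and so goes from 4-methoxyphenyl to 3,4-dimethoxyphenyl. Going by the values given here, no measured step adds a group at this place. The three steps above only exchange one group on the same ring, and they stay modest or within the scatter. The expected step is small: a 1.2-fold lower number from compound 3 to compound 4 (0.06 log units; within the scatter) is estimated, with no move beyond the scatter expected in either direction. For compound 4 the expected value is 7500 nM within 3000 nM to 18000 nM as the estimated range.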

Compound 4, concentration for 50% growth inhibition: 2710 nM
For compound 4 the middle estimate is 2.8-fold (0.44 log units) above the measured one; the whole stated range lies above it.
By their numbers in this assay, from the lowest: compounds 4 and 2 (each within the scatter of the next); then compounds 1 and 3 (each within the scatter of the next).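

In this assay, adding a group at this place on the ring has a measurable effect: the second methoxy of 3,4-dimethoxyphenyl gives a 3.2-fold lower number from compound 3 to compound 4 (0.50 log units; beyond the scatter) (a step in which nothing is exchanged, unlike the earlier ones). Compound 4 cannot be told apart from the 4-hydroxyphenyl compound, with a 1.1-fold lower number from compound 2 to compound 4 (0.03 log units; within the scatter) inside the scatter, while the comparison with the 4-(trifluoromethyl)phenyl compound gives a 2.3-fold lower number from compound 1 to compound 4 (0.35 log units; beyond the scatter) beyond it. No measured evidence accounts for these steps.

On these data alone, whether the step is specific to methoxy remains open. An amine or an ethoxy at the same place could give a similar or a different step.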